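The compounds below may be only part of what the source reports. "The series", "measured", "known", "first", "only" and "open" are said of these compounds alone.

Compound 2 `COc1ccccc1NS(=O)(=O)c1ccc(N2CCNC2=O)cc1` sits at the lower end of the two numbers reported in a functional assay on HT-29 cells (Homo sapiens) for antiproliferative activity, read by sulforhodamine B assay, with a stated time of 48 h; a higher number here means a weaker inhibitor, a lower number a stronger inhibitor: compound 2 gives 550 nM. Compound 1 `CCCCOc1ccc(NS(=O)(=O)c2ccc(N3CCNC3=O)cc2)cc1` is its nearest neighbour, and in this assay compound 1 gives 630 nM, a gap that lies within the scatter, so the two are not separated. Compound 3 `CC(C)(C)c1ccc(NS(=O)(=O)c2ccc(N3CCNC3=O)cc2)cc1` is reported in this assay only as a limit, > 1000 nM (the limit of > 1000 nM in this assay, at which 1 of the 3 values shown sits).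

The step to compound 4 `Cc1cccc(NS(=O)(=O)c2ccc(N3CCNC3=O)cc2)c1` is 3-methylphenyl in place of 2-methoxyphenyl on a sulfonamide nitrogen. Within the data shown here, the one measured step that touches a related change is an at least 1.5-fold higher number from compound 1 to compound 3 (0.20 log units; that floor lies within the scatter), where an alkoxy group on an aromatic carbon gave way to an alkyl group; it reads as at least a modest rise, and its floor is inside the scatter. The change from compound 2 to compound 4 likewise trades a methoxy-bearing ring for a methyl-bearing one, so a small rise in the number, or none beyond the scatter, is expected in this assay, as a 1.5-fold higher number from compound 2 to compound 4 (0.19 log units; within the scatter). For compound 4 in this assay the estimate is 850 nM, between 350 nM and 2100 nM.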

Compound 4, half-maximal inhibitory concentration: 110 nM
Compound 4: middle estimate off by 7.7-fold (0.89 log units), on the high side; the whole stated range lies above it.
By their numbers in this assay, from the lowest: compound 4; then compounds 2 and 1 (each within the scatter of the next). At a limit, above all of these: compound 3.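

In this assay, the group on the sulfonamide nitrogen can move the number well beyond the scatter: a 5.0-fold lower number from compound 2 to compound 4 (0.70 log units; beyond the scatter). Among these compounds, the only earlier step, an at least 1.5-fold higher number from compound 1 to compound 3 (0.20 log units; that floor lies within the scatter), also traded an alkoxy group for an alkyl group, but it pointed the other way, so that trade does not carry one direction across these compounds. Two things change together here, methoxy to methyl and the 2-substituted ring to the 3-substituted one, and nothing at hand accounts for the drop.

As far as these compounds go, it remains open whether the methyl group or its place on the ring carries the step, which 2-methylphenyl or 3-methoxyphenyl on the same nitrogen would separate. Also open, from the compounds shown here alone, is what an amine, a carboxylic acid or a longer chain on that ring would give in this assay.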